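From 2-chloro-4-fluorophenyl to 2,3-difluorophenyl on a ring amine

The source may report more compounds than this note shows. Statements on the series, on what has been measured and on what is new or still open speak of the compounds shown alone.

Of the compounds shown here, three sharing one core have been tested in a functional assay on CHO cells with adenosine receptor A1 (Homo sapiens) as the target, read by cAMP accumulation and immunoassay, with a stated time of 6 min, tested at 0.01 uM; on this read-out higher numbers stand for a weaker effect at the one concentration tested and lower numbers for a stronger effect. Compound 1 `Nc1scc(CN2CCN(c3cc(Cl)cc(Cl)c3)CC2)c1C(=O)c1ccc(Cl)cc1` gives -1%. Compound 2 `Nc1scc(CN2CCN(c3ccc(F)cc3Cl)CC2)c1C(=O)c1ccc(Cl)cc1` gives 6.1%. Compound 3 `Nc1scc(CN2CCN(c3ccccc3C(F)(F)F)CC2)c1C(=O)c1ccc(Cl)cc1` gives 0%. Compound 2 holds the highest of the three numbers, yet every gap between them is small: the step of a number 7.1 percentage points higher from compound 1 to compound 2 (within the scatter), the step of a number 6.1 percentage points lower from compound 2 to compound 3 (within the scatter) and the step of a number 1 percentage points higher from compound 1 to compound 3 (within the scatter) are each within the scatter, so the three compounds cannot be told apart on this read-out, and all three sit near zero effect at the one concentration tested.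

Compound 4 `Nc1scc(CN2CCN(c3cccc(F)c3F)CC2)c1C(=O)c1ccc(Cl)cc1` is not yet measured. It differs from compound 2 in one place: 2,3-difluorophenyl in place of 2-chloro-4-fluorophenyl on an amine nitrogen in a ring. The measured steps that bear on this are the three exchanges of the group on the same amine nitrogen, and none of them moved the number beyond the scatter. The expectation for compound 4 in this assay is therefore a step of a number 4.1 percentage points lower from compound 2 to compound 4 (within the scatter), that is, no change beyond the scatter. Compound 4 is expected to give about 2%, within a range from -8% to 12%.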

Compound 4, a percentage reported as activity, at one concentration (the size of the read-out at that concentration, not a potency): -13%
Estimate against measurement, compound 4: 15 percentage points above; the whole stated range lies above it.
By their numbers in this assay, from the lowest: compound 4; then compounds 1, 3 and 2 (each within the scatter of the next).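

In this assay the group on this amine nitrogen turns out to matter after all: 2,3-difluorophenyl separates compound 4 from each of the other three compounds (a number 19.1 percentage points lower from compound 2 to compound 4 (beyond the scatter)) (a number 13 percentage points lower from compound 3 to compound 4 (beyond the scatter)) (a number 12 percentage points lower from compound 1 to compound 4 (beyond the scatter)), although the three earlier groups could not be told apart. Since lower numbers mean a stronger effect here, compound 4 has the strongest effect of the four at the one concentration tested, and the exchange from compound 2 achieves this with no change in the count of heavy atoms, hydrogen-bond donors or acceptors, so those counts do not separate the two compounds. Nothing available explains why this group behaves differently from the others.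

The compounds shown leave open whether both fluorines are needed, which a plain phenyl, a 2-fluorophenyl or a 3-fluorophenyl on the same nitrogen would help to settle. They also leave open whether a methoxy group on the phenyl ring would give a similar number, and whether the separation of compound 4 would hold at other concentrations, as a single-concentration read-out is not a potency.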